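The compounds below may be only part of what the source reports. "The series", "measured", "known", "first", "only" and "open" are said of these compounds alone.

Measured compounds:
Compound 1, `Brc1cn2ccnc2c(-c2ccc3ncn(C4CCCCC4)c3c2)n1`, gives 10%.
Compound 2, `O=Cc1ccc(-c2cn3ccnc3c(-c3ccc4ncn(C5CCCCC5)c4c3)n2)cc1`, gives 31.5%.
Compound 3, `Clc1ccc(-c2cn3ccnc3c(-c3ccc4ncn(C5CCCCC5)c4c3)n2)cc1`, gives 6.3%.

All three were tested in a functional assay on SF-539 cells (Homo sapiens) for inhibition, read by sulforhodamine B assay, with a stated time of 48 h, tested at 10 uM; on this read-out lower numbers stand for less inhibition and higher numbers for more inhibition at the one concentration tested (going by the name of the read-out). Compound 3 sits at the low end of the set: the step of a number 3.7 percentage points lower from compound 1 to compound 3 (within the scatter) is within the usual scatter, so compound 1 and compound 3 cannot be told apart, while compound 2 stands clearly higher, as the step of a number 25.2 percentage points lower from compound 2 to compound 3 (beyond the scatter) shows.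

Compound 4, `Brc1ccc(-c2cn3ccnc3c(-c3ccc4ncn(C5CCCCC5)c4c3)n2)cc1`, differs from compound 3 in one place: bromo in place of chloro on an aromatic carbon. For the measured compounds named here, no measured step swaps one halogen for another on the phenyl ring. The two steps that touch this part of the molecule are larger changes: a number 3.7 percentage points lower from compound 1 to compound 3 (within the scatter) replaces bromo on the core with the whole 4-chlorophenyl group and stays within the scatter, and a number 25.2 percentage points lower from compound 2 to compound 3 (beyond the scatter) swaps formyl for chloro and moves the number beyond the scatter. Chloro to bromo is a smaller change than either, so compound 4 is expected to stay close to compound 3, with no step beyond the scatter: a number 1.7 percentage points higher from compound 3 to compound 4 (within the scatter). Compound 4 is therefore estimated at 8%, in the range 0% to 20%.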

Compound 4, a percentage reported as inhibition, at one concentration (the size of the read-out at that concentration, not a potency): 24.4%
Estimate against measurement, compound 4: 16.4 percentage points below; the measured number lies above the stated range.
By their numbers in this assay, from the lowest: compounds 3 and 1 (each within the scatter of the next); then compounds 4 and 2 (each within the scatter of the next).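

In this assay, bromo in place of chloro on the six-membered aromatic ring gives a number 18.1 percentage points higher from compound 3 to compound 4 (beyond the scatter), so exchanging one halogen atom at this place is enough to move the number beyond the scatter, something the earlier, larger changes could not reveal. The added ring therefore does not fix the reading on its own: the 4-bromophenyl group gives a number 14.4 percentage points higher from compound 1 to compound 4 (beyond the scatter) against the bromo on the core, while bromo and formyl at the ring position cannot be told apart, with a number 7.1 percentage points lower from compound 2 to compound 4 (within the scatter). Nothing available here explains why bromo and chloro differ at this position.

Open, on these data alone, is whether fluoro, iodo, an amine or a carboxylic acid at this same place would read nearer compound 3 or compound 4. Also open, as far as these compounds go, is whether the gap between bromo and chloro persists at other concentrations.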